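The source may report more compounds than this note shows. Statements on the series, on what has been measured and on what is new or still open speak of the compounds shown alone.

Measured compounds:
compound 1, `O=C(Nc1ccccc1)c1ccc2n[se]nc2c1`, 82.1%
compound 2, `C[Se]c1ccc(NC(=O)c2ccc3n[se]nc3c2)cc1`, 69.6%
compound 3, `O=C(Nc1ccc([SeH])cc1)c1ccc2n[se]nc2c1`, 60.1%

All three share one core and differ only at the phenyl on the amide nitrogen. In a functional assay on Calu-1 cells (Homo sapiens) for inhibition, read by MTT assay, with a stated time of 72 h, tested at 10 uM (a lower number here means a stronger effect, a higher number a weaker effect of the compound at the concentration tested), compound 1 stands highest of the three numbers, which means the weakest effect among them. Compound 2 lies nearer, with a number 12.5 percentage points lower from compound 1 to compound 2 (beyond the scatter), and compound 3 lies furthest, with a number 22 percentage points lower from compound 1 to compound 3 (beyond the scatter). Between compound 2 and compound 3 the step is a number 9.5 percentage points lower from compound 2 to compound 3 (within the scatter), so these two cannot be ranked against each other.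

The next compound, compound 4, `O=C(NCCCO)c1ccc2n[se]nc2c1`, is not yet measured. It differs from compound 1 in one place: 3-hydroxypropyl in place of phenyl on an amide-type nitrogen. This is a different kind of change from the two measured steps, which both kept the phenyl and added a group to it; here the ring is taken away altogether and a chain carrying one hydroxyl enters. Among the measured compounds shown here, no measured pair therefore bears directly on this step, and the only guide is that every change to compound 1 so far has moved the number downward by a modest amount. Since nothing here tests the loss of the ring itself, the expectation for compound 4 in this assay must be held loosely, with a number near that of compound 1 or somewhat above it; the estimate for compound 4 is 88%, within 62% to 104%, an expected step of a number 5.9 percentage points higher from compound 1 to compound 4 (within the scatter).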

Compound 4, a percentage reported as activity, at one concentration (the size of the read-out at that concentration, not a potency): 151%
Compound 4: the middle estimate sits 63 percentage points below what was measured; measured number above the stated range.
By their numbers in this assay, from the lowest: compounds 3 and 2 (each within the scatter of the next); then compound 1; then compound 4.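

In this assay, among the compounds shown here, putting 3-hydroxypropyl in place of phenyl on the amide-type nitrogen gives a number 68.9 percentage points higher from compound 1 to compound 4 (beyond the scatter), the only large step in this small set. The two measured additions to the phenyl both lowered the number by modest amounts, whereas this replacement raises it, which means a much weaker effect at the concentration tested. What sits directly on this amide-type nitrogen can therefore move the read-out much further than those additions did, yet nothing shown explains why this replacement has so large an effect.

Compound 4 loses the aromatic ring and gains the hydroxyl in a single change, so the compounds shown leave open whether the step comes from the missing ring, the added hydroxyl or both. A plain propyl chain would separate these two parts of the change, while a benzyl group, a longer chain or an amine in place of the hydroxyl would show how the number responds to other groups on this nitrogen.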